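This account rests on a few compounds, and the source may have more. Where it says the series, first, only, none or still open, it means among the compounds named here.

Working notes on the series. All members share the core of compound 1 `COc1ccc(-c2cc(=O)c3c(OC)cc(OC)cc3n2C)cc1`, for which a functional assay on HepG2 cells (Homo sapiens) for antiproliferative activity, with a stated time of 72 h (on this read-out higher numbers stand for an effect only at larger amounts of compound and lower numbers for an effect already at smaller amounts), records "not determined" (no result reported) for compound 1. Compound 2 `COc1ccc(-c2cc(=O)c3c(OC)cc(OC)cc3n2S(=O)(=O)c2cccc([N+](=O)[O-])c2)cc1` bears a 3-nitrophenyl on the sulfonyl sulfur; in this assay compound 2 gives only a limit, > 39600 nM. Compound 3 `COc1ccc(-c2cc(=O)c3c(OC)cc(OC)cc3n2S(=O)(=O)c2ccc(F)cc2)cc1` bears a 4-fluorophenyl on the same sulfur; in this assay compound 3 again gives only a limit, > 65500 nM. For the measured compounds named here, the single measured step, a step that the two limits leave unreadable from compound 2 to compound 3, is unreadable, both ends being limits the limit of > 39600 nM in this assay, at which 1 of the 3 values shown sits (the limit of > 65500 nM in this assay, at which 1 of the 3 values shown sits). Compound 3 thus stands at a limit, with no numbered value anywhere in the series to rank it against.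

Compound 4 `COc1ccc(-c2cc(=O)c3c(OC)cc(OC)cc3n2S(=O)(=O)c2cc(Cl)cc(Cl)c2O)cc1` differs from compound 3 by 3,5-dichloro-2-hydroxyphenyl in place of 4-fluorophenyl on a sulfonyl sulfur. No measured step sizes a change on this sulfur, so the expectation rests on compound 3 at its limit > 65500 nM and compound 2 at its limit > 39600 nM. Compound 4 is expected to give about 60000 nM, between 10000 nM and 200000 nM, most likely again as a limit. The expected step is an at least 1.0-fold lower number from compound 3 to compound 4 (0.03 log units; that floor lies within the scatter), not readable beyond the scatter.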

Compound 4, half-maximal effective concentration: > 37900 nM
Compound 4 was reported as a limit (the forecaster's own chance of this, stated with the estimate: 70%); the middle value is on the limit's open side.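

In this assay compound 4 gives only a limit, > 37900 nM, and the steps to compound 4 from compound 2 and from compound 3 cannot be read. The compounds shown leave open how compounds 2, 3 and 4 rank, and whether any group on the sulfonyl sulfur gives a numbered value in this assay.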